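The source may report more compounds than this note shows. Statements on the series, on what has been measured and on what is new or still open speak of the compounds shown alone.

Measured compounds:
- Compound 1, `O=C(Nc1cccc(-n2cc(-c3ccncc3)c(-c3cc(O)cc(Cl)c3)n2)c1)Nc1ccc(Cl)c(Cl)c1`: -33.3%
- Compound 2, `COc1cc(Cl)cc(-c2nn(-c3cccc(NC(=O)Nc4ccc(Cl)c(Cl)c4)c3)cc2-c2ccncc2)c1`: 0.46%
- Compound 3, `O=C(Nc1cccc(-n2cc(-c3ccncc3)c(-c3cc(O)cc(Cl)c3)n2)c1)c1cc(C(F)(F)F)cc(C(F)(F)F)c1`: 45.6%

Of the compounds shown here, three have been measured in a functional assay on MDA-MB-435 cells (Homo sapiens) for inhibition, read by sulforhodamine B assay, with a stated time of 48 h, tested at 10 uM; on this read-out higher numbers stand for a weaker effect at the one concentration tested and lower numbers for a stronger effect. Compound 1 gives -33.3% in this assay, and compound 2 gives 0.46%. The two differ in a single place, described as methyl in place of hydrogen on an oxygen on an aromatic ring, and this change brings a step of a number 33.8 percentage points higher from compound 1 to compound 2 (beyond the scatter), a large shift towards weaker effect that lies beyond the usual scatter.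

Compound 3 gives 45.6% in this assay, the highest of the three numbers. Its two neighbours are compound 2, whose value is below it beyond the scatter, and compound 1, whose value is much further below it. How the core of compound 3 differs from the core of compound 1 is not broken down here; the two differ in more than one place.

Compound 4, `COc1cc(Cl)cc(-c2nn(-c3cccc(NC(=O)c4cc(C(F)(F)F)cc(C(F)(F)F)c4)c3)cc2-c2ccncc2)c1`, has not yet been measured. It differs from compound 3 by methyl in place of hydrogen on an oxygen on an aromatic ring, and the place of the change is given in the same words as for the change from compound 1 to compound 2, so this is the same change made a second time, now on the core of compound 3. On the strength of the step of a number 33.8 percentage points higher from compound 1 to compound 2 (beyond the scatter) in this assay, compound 4 is expected to move in the same direction as that earlier step, though the starting point of compound 3 already sits high and the read-out cannot rise without bound. The expected step is a number 29.4 percentage points higher from compound 3 to compound 4 (beyond the scatter). Compound 4 is therefore estimated at 75% in this assay, within a range from 50% to 100%.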

Compound 4, a percentage reported as activity, at one concentration (the size of the read-out at that concentration, not a potency): 80%
The estimate for compound 4 lay 5 percentage points below the measured number, within the range that was stated.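

Replacing hydroxy with methoxy on the 3-chloro-5-hydroxyphenyl group gives a large step on the core of compound 3, a number 34.4 percentage points higher from compound 3 to compound 4 (beyond the scatter), in this assay, and it matches the step seen earlier on the core of compound 1: the same change on two cores in this assay, a number 33.8 percentage points higher (beyond the scatter) from compound 1 to compound 2 and a number 34.4 percentage points higher (beyond the scatter) from compound 3 to compound 4, 0.6 percentage points apart, within the scatter of two such steps. Within these two pairs, then, the change carries from one core to the other as a shift of the same size towards weaker effect at the one concentration tested. Among the compounds shown here, this rests on only two pairs, however, so it does not show that the shift would hold on any further core, and it does not explain why the methoxy compounds read weaker than their hydroxy partners.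

The compounds shown carry only hydroxy or methoxy in this place, so it remains open how an ethoxy group, an amine or a fluorine atom there would read in this assay. As far as these compounds go, it is also open whether the step would keep its size if the chlorine of the 3-chloro-5-methoxyphenyl group gave way to a methyl group, or at a concentration other than the single one used here.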